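Anilino series on the shared core: toward compound 4

The source may report more compounds than this note shows. Statements on the series, on what has been measured and on what is new or still open speak of the compounds shown alone.

Measured so far:
compound 1, `COc1ccc(Nc2nc(N[C@H]3CC[C@H](N)CC3)nc3c2ncn3CCC(C)C)c(OC)c1`, 7900 nM
compound 2, `CC(C)CCn1cnc2c(Nc3ccc(Cl)cc3)nc(N[C@H]3CC[C@H](N)CC3)nc21`, 5100 nM
compound 3, `CC(C)CCn1cnc2c(NCc3cccc(Cl)c3)nc(N[C@H]3CC[C@H](N)CC3)nc21`, 6600 nM

All three numbers come from a functional assay on BT-474 cells (Homo sapiens) for inhibition, read by fluorescence, with a stated time of 72 h; a lower number here means a stronger inhibitor of growth, a higher number a weaker inhibitor of growth. Compound 3 sits close to both neighbours: a 1.2-fold lower number from compound 1 to compound 3 (0.08 log units; within the scatter) and a 1.3-fold higher number from compound 2 to compound 3 (0.11 log units; within the scatter) are each within the scatter, as is a 1.5-fold lower number from compound 1 to compound 2 (0.19 log units; within the scatter). Across the three compounds, changing the group on the nitrogen on the aromatic ring has so far moved nothing beyond the scatter.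

Compound 4, `CC(C)CCn1cnc2c(Nc3ccccc3)nc(N[C@H]3CC[C@H](N)CC3)nc21`, is not yet measured. Its change from compound 3 is phenyl in place of 3-chlorobenzyl on a nitrogen on an aromatic ring. The step that bears most directly on it is a 1.3-fold higher number from compound 2 to compound 3 (0.11 log units; within the scatter), which also exchanges the substituent on that same nitrogen and stayed within the scatter; a 1.5-fold lower number from compound 1 to compound 2 (0.19 log units; within the scatter) and a 1.2-fold lower number from compound 1 to compound 3 (0.08 log units; within the scatter) point the same way. Among the compounds with values here, no measured step at this position is beyond the scatter, so no step beyond the scatter is expected for compound 4 in this assay.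

Compound 4 is therefore expected at about 5500 nM, with a range of 2500 nM to 12000 nM. The expected step of a 1.2-fold lower number from compound 3 to compound 4 (0.08 log units; within the scatter) is estimated to lie within the scatter.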

Compound 4, concentration for 50% growth inhibition: 6400 nM
Beside the measured number, compound 4's estimate is 1.2-fold (0.07 log units) below it, and the stated range covers the measured number.
By their numbers in this assay, from the lowest: compounds 2, 4, 3 and 1 (each within the scatter of the next).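

In this assay, the unsubstituted phenyl on this nitrogen reads like its chlorinated counterpart, with hydrogen in place of chloro on an aromatic carbon (a 1.3-fold higher number from compound 2 to compound 4 (0.10 log units; within the scatter)). The (3-chlorobenzyl)amino to anilino change (a 1.0-fold lower number from compound 3 to compound 4 (0.01 log units; within the scatter)) and the loss of both methoxy groups (a 1.2-fold lower number from compound 1 to compound 4 (0.09 log units; within the scatter)) also stay within the scatter, so all four groups now read alike, including a ring with no substituent at all. Nothing shown offers an explanation for this flat reading.

As far as these compounds go, whether any group on this nitrogen can move the number beyond the scatter remains open, for example a carboxylic acid or an aminoethyl chain on the phenyl ring. From the compounds shown here alone, the rest of the shared core is the same in all four compounds, so its contribution to growth inhibition in this assay also remains open.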